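Adding a Second Chloro Group: From Compound 2 to Compound 4

The source may hold more compounds than are shown below. What is called first, only, known or untested is meant among the compounds shown, and "the series" means these compounds.

Of the compounds shown here, three built on the same core have been tested in a functional assay on the whole organism (strain Swiss albino) with Mus musculus as the target, in the maximal electroshock model, with a stated time of 4 h; a lower number here means that less compound is needed, a higher number that more compound is needed for the effect. Compound 1 `COc1ccc(/C=N/NC(=O)Nc2cccc3ccccc23)cc1OC` gives 100 mg/kg, and compound 3 `CN(C)c1ccc(/C=N/NC(=O)Nc2cccc3ccccc23)cc1` gives 100 mg/kg. Compound 2 `C/C(=N\NC(=O)Nc1cccc2ccccc12)c1ccc(Cl)cc1` gives 300 mg/kg, the highest of the three numbers: its gap to compound 1 and its gap to compound 3 are each wider than the usual scatter of this kind of measurement, so compound 2 needs clearly more material than either of the others to protect the animals in this test.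

Compound 4 `C/C(=N\NC(=O)Nc1cccc2ccccc12)c1ccc(Cl)cc1Cl` has not been tested yet. It differs from compound 2 in a single place: chloro in place of hydrogen on an aromatic carbon

Among the measured compounds shown here, no pair of measured compounds shows this particular change, so there is no measured step to lean on, and the direction must be guessed from the general pattern that small additions of this sort in this test tend to shift the dose only modestly. The change expected from compound 2 to compound 4 is a 1.5-fold lower number from compound 2 to compound 4 (0.18 log units; within the scatter), a small shift toward a lower number that may not clearly exceed the scatter. Compound 4 is accordingly estimated to give about 200 mg/kg in this assay, with a plausible range from 100 mg/kg to 400 mg/kg.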

Compound 4, minimum effective dose: 300 mg/kg
For compound 4 the middle estimate is 1.5-fold (0.18 log units) below the measured one, and the stated range covers the measured number.
By their numbers in this assay, from the lowest: compounds 1 and 3 (each within the scatter of the next); then compounds 2 and 4 (each within the scatter of the next).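

In this assay, among the compounds shown here, turning 4-chlorophenyl into 2,4-dichlorophenyl gives no change at the digits printed from compound 2 to compound 4 (within the scatter) and is the first measured change in a single place, since no two of the earlier compounds differed in only one place. It shows that a chloro group can take the place of hydrogen on this aromatic carbon, ortho to a large group and meta to a chloro group, without clearly shifting the dose needed for protection in this test. Nothing measured here explains why this added chlorine leaves the dose where it was.

Going by these compounds, whether a fluoro group, a methoxy group or an amine on the same aromatic carbon would leave the dose just as unmoved remains open, so this single step cannot say whether the place tolerates substituents in general or only a chloro group. Also open, on these data alone, is whether adding a chloro group at this place would have the same outcome on a compound with a different substituent pattern on that ring, such as compound 3, whose dimethylamino group stands in the same series.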